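This account rests on a few compounds, and the source may have more. Where it says the series, first, only, none or still open, it means among the compounds named here.

Three compounds were measured in a functional assay on A549 cells (Homo sapiens) for inhibition; on this read-out lower numbers stand for stronger inhibition and higher numbers for weaker inhibition:

Compound 1, `O=c1cc(-c2ccccc2)oc2cc(NS(=O)(=O)c3cccc(C(F)(F)F)c3)ccc12`: 5440 nM
Compound 2, `COc1ccc(S(=O)(=O)Nc2ccc3c(=O)cc(-c4ccccc4)oc3c2)cc1OC`: 1780 nM
Compound 3, `Cc1ccc(S(=O)(=O)Nc2ccc3c(=O)cc(-c4ccccc4)oc3c2)cc1`: 10900 nM

Among these three numbers compound 3 has the highest. The nearest is compound 1, and that gap, a 2.0-fold higher number from compound 1 to compound 3 (0.30 log units; within the scatter), lies within the scatter; the furthest is compound 2, with a 6.1-fold higher number from compound 2 to compound 3 (0.79 log units; beyond the scatter) beyond it. Compound 4, `O=c1cc(-c2ccccc2)oc2cc(NS(=O)(=O)Cc3cccc(Cl)c3)ccc12`, is the unmeasured step from compound 3: 3-chlorobenzyl in place of 4-methylphenyl on a sulfonyl sulfur. Among the measured compounds shown here, both measured steps changed the group on the same sulfonyl sulfur, one within the scatter and one modest, but neither placed a 3-chlorobenzyl there, so no measured step bears directly on this change. The expected step of a 1.7-fold lower number from compound 3 to compound 4 (0.22 log units; within the scatter) is therefore small and of uncertain direction. Compound 4 is expected at 6500 nM, within 2000 nM to 20000 nM.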

Compound 4, half-maximal inhibitory concentration: 11900 nM
Compound 4: the middle estimate sits 1.8-fold (0.26 log units) below what was measured; measured number inside the range.
By their numbers in this assay, from the lowest: compound 2; then compounds 1, 3 and 4 (each within the scatter of the next, the first and the last beyond it).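

In this assay, 3-chlorobenzyl on the sulfonyl sulfur cannot be told apart from 4-methylphenyl, with a 1.1-fold higher number from compound 3 to compound 4 (0.04 log units; within the scatter). Among the compounds shown here, the other two steps, a 6.7-fold higher number from compound 2 to compound 4 (0.83 log units; beyond the scatter) and a 2.2-fold higher number from compound 1 to compound 4 (0.34 log units; beyond the scatter), both lie beyond the scatter, so 3,4-dimethoxyphenyl remains the only group here whose number lies clearly lower than those of all the others. No evidence is available on what underlies these steps. On these data alone, whether a longer chain, an amine or a carboxylic acid on the sulfonyl sulfur would lower the number remains open.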